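The source may report more compounds than this note shows. Statements on the series, on what has been measured and on what is new or still open speak of the compounds shown alone.

Measured compounds:
Compound 1, `O=C(CCCCC1CCSS1)NCc1cn(CCCOc2ccc3cc(C(=O)O)c(=O)oc3c2)nn1`, gives 66.8%.
Compound 2, `O=C(CCCCC1CCSS1)NCc1cn(CCCCOc2ccc3cc(-c4ccccc4)c(=O)oc3c2)nn1`, gives 26%.

Both numbers come from a functional assay on PC-12 cells (Rattus norvegicus) for cytotoxicity, read by MTT assay, with stated times of 3 h and 2 h, tested at 20 uM; on this read-out lower numbers stand for a weaker effect and higher numbers for a stronger effect at the one concentration tested. Compound 2 holds the lower of the two values, and compound 1 stands above it by a gap beyond the usual scatter of this kind of measurement.

Compound 3, `O=C(CCCCC1CCSS1)NCc1cn(CCCCOc2ccc3cc(-c4ccc(Cl)cc4)c(=O)oc3c2)nn1`, has not yet been measured. It differs from compound 2 in one place only: chloro in place of hydrogen on an aromatic carbon. Everything else in the molecule is the same. Within the data shown here, no pair of measured compounds differs in this one place alone, so there is no measured step to show what such an exchange does in this setting; the two numbers from compound 1 and compound 2 say only that those two values differ.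

With nothing pointing either way, the step expected in this assay is small, a number 4 percentage points higher from compound 2 to compound 3 (within the scatter), a change not beyond the scatter. Compound 3 is therefore expected to give about 30%, with a likely range from 14% to 50%.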

Compound 3, a percentage reported as activity, at one concentration (the size of the read-out at that concentration, not a potency): 68.4%
Compound 3: the middle estimate sits 38.4 percentage points below what was measured; measured number outside the range, above it.
By their numbers in this assay, from the lowest: compound 2; then compounds 1 and 3 (each within the scatter of the next).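

In this assay, the change from phenyl to 4-chlorophenyl gives a number 42.4 percentage points higher from compound 2 to compound 3 (beyond the scatter), so this site on the aromatic ring is one where a single added chlorine atom can strongly change the read-out. The two earlier compounds differ from each other in more than one place, so they could not show what any single exchange does; this pair isolates one change, and everything else in the molecule stays the same. No measurement available here explains why one chlorine atom has so large an effect in this assay.

This single step cannot show whether the effect is particular to chloro, since the compounds shown do not include a fluoro, methoxy or carboxylic acid group at the same place, or chloro on another carbon of the ring. They also leave open whether the same exchange would give a step of similar size with a longer chain in the linker, or at other concentrations, since the read-out comes from one concentration and is not a potency.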